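Swapping the pendant aryl group in a statin-like lactone

The source may hold more compounds than are shown below. What is called first, only, known or untested is meant among the compounds shown, and "the series" means these compounds.

Three compounds in this set share a lactone head group joined through a two-carbon linker to a substituted aromatic core that carries a second aromatic ring. In an assay for inhibition of 3-hydroxy-3-methylglutaryl-coenzyme A reductase (Rattus norvegicus) (a higher number here means a weaker inhibitor, a lower number a stronger inhibitor), compound 1 `COc1ccc(-c2cc(Cl)cc(Cl)c2/C=C/[C@@H]2C[C@@H](O)CC(=O)O2)cc1` gives 470 nM, the highest number of the three. Compound 2 `Cc1ccc(C)c(-c2ccc(Cl)c(Cl)c2)c1/C=C/[C@@H]1C[C@@H](O)CC(=O)O1` gives 13 nM in this assay, a clearly lower number, and compound 3 `Cc1cc(C)c(/C=C/[C@@H]2C[C@@H](O)CC(=O)O2)c(-c2ccc(F)c(CO)c2)c1` gives 49 nM, also a lower number; both gaps lie beyond the usual scatter. Compound 4 `CCc1cccc(-c2cc(Cl)cc(Cl)c2/C=C/[C@@H]2C[C@@H](O)CC(=O)O2)c1` has not yet been measured. It differs from compound 1 in one place: 3-ethylphenyl in place of 4-methoxyphenyl on an aromatic carbon. For the measured compounds named here, no measured pair in this set isolates that change, so its effect can only be guessed. Since compound 1 already stands at 470 nM, the step is expected to be modest and toward a lower number, estimated as a 1.9-fold lower number from compound 1 to compound 4 (0.27 log units; within the scatter). Compound 4 is therefore expected to give about 250 nM in this assay, within a range of 80 nM to 800 nM.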

Compound 4, half-maximal inhibitory concentration: 44 nM
The estimate for compound 4 lay 5.7-fold (0.75 log units) above the measured number; the whole stated range lies above it.
By their numbers in this assay, from the lowest: compound 2; then compounds 4 and 3 (each within the scatter of the next); then compound 1.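

In this assay, for the compounds shown here, replacing 4-methoxyphenyl with 3-ethylphenyl on the shared core gives an 11-fold lower number from compound 1 to compound 4 (1.03 log units; beyond the scatter) and shows that this position responds strongly to the choice of pendant ring, which the earlier compounds could not show, as they differ from one another in more than one place. The change swaps the substituent and moves it on the ring at once, so this single step cannot be divided between those two differences. Nothing available explains why the step is this large.

The compounds shown leave open whether the step follows the ethyl group or its ring position, a question that a 3-methoxyphenyl or 4-ethylphenyl group would help settle. Also open, going by these compounds, is how this position would respond to an amine, a carboxylic acid or a longer chain on the pendant ring.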